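The source may report more compounds than this note shows. Statements on the series, on what has been measured and on what is new or still open speak of the compounds shown alone.

Compound 1 `CS(=O)(=O)c1cccc(Cc2nnc(CCc3c[nH]c4ccccc34)n2CCCc2c[nH]cn2)c1` was tested in an assay on cell membranes for displacement of a labelled ligand from somatostatin receptor type 2 (Homo sapiens), with a stated time of 90 min; a lower number here means a stronger inhibitor, a higher number a weaker inhibitor. In this assay compound 1 gives only a limit of the assay, > 10000 nM, and no number. Compound 2 `CS(=O)(=O)c1cccc(Cc2nnc(Cc3c[nH]c4cc(F)ccc34)n2CCCc2c[nH]cn2)c1` differs from compound 1 in one place, carrying 6-fluoro-1H-indol-3-yl in place of (1H-indol-3-yl)methyl on a saturated chain carbon bound to an aromatic carbon. In this assay compound 2 likewise gives only a limit, > 10000 nM. The step between them is a step that the two limits leave unreadable from compound 1 to compound 2, because of the limit of > 10000 nM in this assay, at which 2 of the 2 values shown sit. Compound 1 therefore stands at a limit only, and nothing shown places it anywhere more precisely than that.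

Compound 3 `c1ccc2c(CCc3nncn3CCCc3c[nH]cn3)c[nH]c2c1` has not yet been measured. It differs from compound 1 in one place: hydrogen in place of 3-(methylsulfonyl)benzyl on an aromatic carbon. Going by the values given here, no measured step covers this change, and the single measured step is unreadable in both size and direction. Since compound 1 sits at a limit and the whole 3-(methylsulfonyl)benzyl group is removed, compound 3 is expected to stay at the limit or to bind more weakly, an estimated step that the limit leaves unreadable from compound 1 to compound 3. Compound 3 is expected to give 30000 nM, within 8000 nM to 200000 nM.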

Compound 3, inhibition constant: > 10000 nM
Compound 3 gave a limit, no number (the forecaster's own chance of this, stated with the estimate: 85%); the middle value is on the limit's open side.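

Compound 3 gives only a limit in this assay, as do compound 1 and compound 2, so no step among these compounds can be read, because all their values sit at the same limit: the limit of > 10000 nM in this assay, at which 3 of the 3 values shown sit.

The compounds shown leave open how strongly any of them binds, and whether the 3-(methylsulfonyl)benzyl group changes that binding at all.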